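Methyl shift on the dimethylpyrazole of compound 1

The source may hold more compounds than are shown below. What is called first, only, known or untested is meant among the compounds shown, and "the series" means these compounds.

Three compounds of the series carry numbers in an assay on isolated protein for inhibition of Leucine-rich repeat serine/threonine-protein kinase 2 variant G2019S (Homo sapiens), read by TR-FRET and LanthaScreen, with stated times of 50 min and 30 min, in the presence of a further agent that is not named here; a lower number here means a stronger inhibitor, a higher number a weaker inhibitor. Compound 1 `Cc1nn(C)cc1Nc1nc(N)c2c(C#N)c(N3CCC[C@H]3C)n(C)c2n1` gives 30 nM. Compound 2 `C[C@@H]1CCCN1c1c(C#N)c2c(N)nccc2n1C` gives 28 nM, a number within the scatter of that of compound 1, so the two are not told apart. Compound 3 `Cn1c(NCc2ccccc2)c(C#N)c2c(N)ncnc21` gives 3530 nM, a far higher number than compound 1 and beyond the scatter. Compound 1 thus holds the second highest of the three numbers, close to compound 2 and far from compound 3. Going by the values given here, no pair among the three differs in a single place, so no measured step is at hand. Compound 4 `Cc1c(Nc2nc(N)c3c(C#N)c(N4CCC[C@H]4C)n(C)c3n2)cnn1C` differs from compound 1 in one group only: 1,5-dimethyl-1H-pyrazol-4-yl in place of 1,3-dimethyl-1H-pyrazol-4-yl on a nitrogen on an aromatic ring The same atoms are joined differently, with the donor and acceptor counts unchanged. With no measured step of this kind in the series, the expected step of a 1.1-fold higher number from compound 1 to compound 4 (0.03 log units; within the scatter) is none beyond the scatter. Compound 4 is therefore expected at 32 nM, within a range of 12 nM to 85 nM.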

Compound 4, half-maximal inhibitory concentration: 43 nM
Compound 4: middle estimate off by 1.3-fold (0.13 log units), on the low side; measured number inside the range.
By their numbers in this assay, from the lowest: compounds 2, 1 and 4 (each within the scatter of the next); then compound 3.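

Going by these compounds alone, the step of a 1.4-fold higher number from compound 1 to compound 4 (0.16 log units; within the scatter) is the first measured change at this position in this assay. On this core, the 1,5-dimethyl-1H-pyrazol-4-yl and 1,3-dimethyl-1H-pyrazol-4-yl groups on the aromatic-ring nitrogen are not told apart, so the placement of this methyl group shows no effect beyond the scatter in this pair. No measurement is at hand to bear on why the two read alike.

This single step leaves open whether the same holds for other groups in that place, such as a pyrazole carrying only one methyl, a 1-ethyl-substituted pyrazole or a phenyl ring. It also leaves open whether the same methyl shift reads alike with a group other than the methylpyrrolidine of compound 1 on the shared core.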